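Swapping Methoxy for Nitro in Compound 1

The source may hold more compounds than are shown below. What is called first, only, known or untested is meant among the compounds shown, and "the series" means these compounds.

Compound 1 `COc1ccc(/C=C/C(=O)OC/C=C/c2ccc(OC)c(OC)c2)cc1` gives > 100 ug/mL in a functional assay on A549 cells (Homo sapiens) for cytotoxicity, read by MTT assay, with a stated time of 72 h (a lower number here means a stronger inhibitor, a higher number a weaker inhibitor), which is a limit of the assay and not a number. Compound 2 `COCOc1ccc(/C=C/C(=O)OC/C=C/c2ccc(OC)cc2)cc1` also reaches only a limit, > 100 ug/mL. Compound 3 `COCOc1ccc(/C=C/C(=O)OC/C=C/c2ccccc2)cc1OCOC` likewise gives a limit, > 100 ug/mL. So compound 1 has no exact value, and the whole picture so far is the limit of > 100 ug/mL in this assay, at which 3 of the 3 values shown sit. None of these three compounds can be ranked against the others.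

Compound 4 `COc1ccc(/C=C/COC(=O)/C=C/c2ccc([N+](=O)[O-])cc2)cc1OC` keeps the core of compound 1 and changes one place, para to a large group: nitro in place of methoxy on an aromatic carbon, turning 4-methoxyphenyl into 4-nitrophenyl (nitro in place of methoxy on an aromatic carbon). Within the data shown here, no measured pair shows what a single change of this kind does in this assay. The expected size of the step is small, and any movement is expected toward a stronger inhibitor: an at least 1.1-fold lower number from compound 1 to compound 4 (0.04 log units; that floor lies within the scatter). Another result given only as a limit would be no surprise. For compound 4 the estimated value is 90 ug/mL, with an expected range from 35 ug/mL to 150 ug/mL.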

Compound 4, half-maximal inhibitory concentration: > 100 ug/mL
Compound 4: only a limit was reported (the forecaster's own chance of this, stated with the estimate: 60%); middle value at least 1.1-fold (0.04 log units) away from the limit.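

Compound 1 and compound 4 both give only a limit of the assay, so no step can be read for nitro in place of methoxy. The compounds shown leave open whether this change shifts cytotoxicity at all, and how any of them ranks against the others: the limit of > 100 ug/mL in this assay, at which 4 of the 4 values shown sit.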